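Another Methyl on the Nine-Carbon Chain

The compounds below may be only part of what the source reports. "The series", "measured", "known", "first", "only" and "open" are said of these compounds alone.

Compound 1 `CCCCCCCCCOC1=C(O)OC(C(O)CO)C1=O`: 0.027 nM
Compound 2 `CCCCCCCCCCOC1=C(O)OC(C(O)CO)C1=O`: 13000 nM

In a functional assay (brain) for inhibition, with Rattus norvegicus as the target (on this read-out higher numbers stand for weaker inhibition and lower numbers for stronger inhibition), compound 2 gives the highest number of the two measured compounds, far above compound 1. Compound 3 `CCCCCCCCCCCOC1=C(O)OC(C(O)CO)C1=O` differs from compound 2 by methyl in place of hydrogen on a saturated chain carbon, ten or more bonds along the chain from an oxygen on an unsaturated carbon. Going by the values given here, the only measured step of this kind is a 480000-fold higher number from compound 1 to compound 2 (5.68 log units; beyond the scatter), an enormous rise for a single added methyl. Nothing shows whether such a rise repeats with a further methyl, so compound 3 is expected to sit near or somewhat above compound 2, a 1.5-fold higher number from compound 2 to compound 3 (0.19 log units; within the scatter), with a wide margin. The estimate for compound 3 is 20000 nM, between 1000 nM and 200000 nM.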

Compound 3, half-maximal inhibitory concentration: 13000 nM
Compound 3: middle estimate off by 1.5-fold (0.19 log units), on the high side; the measured number falls inside the stated range.
By their numbers in this assay, from the lowest: compound 1; then compounds 2 and 3 (each within the scatter of the next).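

In this assay, the added methyl on a saturated chain carbon leaves the number in place (no change at the digits printed from compound 2 to compound 3 (within the scatter)), so the large rise of the previous methyl does not repeat here. Ethyl in place of hydrogen on compound 1 (a 480000-fold higher number from compound 1 to compound 3 (5.68 log units; beyond the scatter)) therefore gives the same large rise as the single methyl. No measurement here explains either result. As far as these compounds go, whether a longer chain, or an amine or a carboxylic acid in place of this methyl, would move the number remains open.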